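Swapping Methoxy for Chloro: Cytotoxicity at the Assay Limit

A few compounds are considered here, and "the series" means these few. Any claim that something is new, unique, unknown or untested is made for them only; others in the source may bear on it.

Compound 1 `CCCCC#Cc1c(C)[nH]c2ccc(OC)cc2c1=O`: in an ADME assay on J774 cells (Mus musculus) for cytotoxicity (on this read-out lower numbers stand for an effect already at smaller amounts and higher numbers for an effect only at larger amounts of compound), compound 1 gives > 36800 nM, a limit of the assay rather than a number.
Compound 2 `CCCCC#Cc1c(C)[nH]c2ccc(Cl)cc2c1=O`: compound 2 gives > 36300 nM, again only a limit.
Compound 3 `COc1ccc2[nH]c(C)c(Cc3ccccc3)c(=O)c2c1`: compound 3 gives > 23700 nM, also a limit.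

Compound 1 and compound 2 differ by chloro in place of methoxy on an aromatic carbon; the step that the two limits leave unreadable from compound 1 to compound 2 cannot be read, since both sit at limits (the limit of > 36800 nM in this assay, at which 1 of the 3 values shown sits, (the limit of > 36300 nM in this assay, at which 1 of the 3 values shown sits)). Compound 3 differs from compound 1 in its core by benzyl in place of hex-1-yn-1-yl on an aromatic carbon, and it too rests at a limit (the limit of > 23700 nM in this assay, at which 1 of the 3 values shown sits). Compound 4 `Cc1[nH]c2ccc(Cl)cc2c(=O)c1Cc1ccccc1` is not yet measured; it is reached from compound 3 by chloro in place of methoxy on an aromatic carbon, the same change as from compound 1 to compound 2, at a place described in the same words. Given that compound 1 and compound 2 both stand at limits the limit of > 36800 nM in this assay, at which 1 of the 3 values shown sits, the limit of > 36300 nM in this assay, at which 1 of the 3 values shown sits, and compound 3 as well (the limit of > 23700 nM in this assay, at which 1 of the 3 values shown sits), a small step is expected in this assay: a step that the limit leaves unreadable from compound 3 to compound 4. Compound 4 is therefore estimated at about 40000 nM, likely between 15000 nM and 150000 nM, and most probably reported only as a limit.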

Compound 4, half-maximal effective concentration: > 35200 nM
Compound 4: only a limit was reported; the forecaster's own chance of this, stated with the estimate: 80%; the middle value lies beyond the limit too.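

In this assay compound 3 and compound 4 both stand at limits, so no step can be read between them. The compounds shown leave open what chloro in place of methoxy changes here, and at which concentration any of them would show an effect.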